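A few compounds are considered here, and "the series" means these few. Any claim that something is new, unique, unknown or untested is made for them only; others in the source may bear on it.

Compound 1 `Cc1cc(C(=O)O)c(C)n1-c1cccc(C2CC2)c1` and compound 3 `O=C(O)C1CCN(c2cccc(C(F)(F)F)c2)C1` rest on different cores; the difference between the two cores is not broken down here. In an assay on cells for inhibition of Palmitoleoyl-protein carboxylesterase NOTUM variant C330S (Homo sapiens), read by fluorescence, with a stated time of 40 min (a lower number here means a stronger inhibitor, a higher number a weaker inhibitor), compound 1 gives 580 nM, while compound 3 gives 11000 nM. Compound 2 `Cc1cc(C(=O)O)c(C)n1-c1cccc(C2CC2)c1F` carries the change fluoro in place of hydrogen on an aromatic carbon and in this assay compound 2 gives 200 nM, a step of a 2.9-fold lower number from compound 1 to compound 2 (0.46 log units; beyond the scatter). Compound 4 `O=C(O)C1CCN(c2cccc(C(F)(F)F)c2F)C1` carries the change fluoro in place of hydrogen on an aromatic carbon on the core of compound 3. This is the same kind of change, not the same: in compound 2 the fluoro sits ortho to a cyclopropyl group and ortho to a large group, in compound 4 ortho to a group of 8 heavy atoms and ortho to a trifluoromethyl group. For the measured compounds named here, only one measured example of this change exists, on a different core. For compound 4 a step of a 2.2-fold lower number from compound 3 to compound 4 (0.34 log units; beyond the scatter) in this assay is expected, resting on a 2.9-fold lower number from compound 1 to compound 2 (0.46 log units; beyond the scatter) and tempered by the change of core. Compound 4 is therefore estimated at 5000 nM in this assay, with a range from 2000 nM to 12000 nM.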

Compound 4, half-maximal inhibitory concentration: 6800 nM
Compound 4: the middle estimate sits 1.4-fold (0.13 log units) below what was measured; low and high end bracket the measured number.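

In this assay, fluoro in place of hydrogen on an aromatic carbon gives a 1.6-fold lower number from compound 3 to compound 4 (0.21 log units; within the scatter), so on this core the step alone does not stand clear of the scatter. For the compounds shown here, this rests on only two examples, on two cores and with the fluoro in different surroundings, so it is no general rule and does not fix the size of the step on a further core. What it does show is that the two steps cannot be told apart, and carrying the change across cores is not contradicted: the same change on two cores in this assay, a 2.9-fold lower number (0.46 log units; beyond the scatter) from compound 1 to compound 2 and a 1.6-fold lower number (0.21 log units; within the scatter) from compound 3 to compound 4, 1.8-fold (0.25 log units) apart, within the scatter of two such steps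

Open, as far as these compounds go, is whether a chloro or a methoxy group in place of that hydrogen would behave as fluoro does on either core. Also open, from the compounds shown here alone, is whether a third core would give a step of similar size.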